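Swapping the benzyl group on the amide of compound 2

The compounds below may be only part of what the source reports. "The series", "measured", "known", "first", "only" and "open" are said of these compounds alone.

Measured in a functional assay on A2780 cells (Homo sapiens) for antiproliferative activity, read by resazurin assay, with a stated time of 72 h; a higher number here means a weaker inhibitor, a lower number a stronger inhibitor:
- compound 1 `Cc1cccc(Cc2n[nH]c3cc(O)c(C(=O)N(C)Cc4ccccc4Br)cc23)c1`: 310 nM
- compound 2 `COc1ccc(CN(C)C(=O)c2cc3c(Cc4cccc(C)c4)n[nH]c3cc2O)cc1OC`: 3700 nM

Compound 2 holds the higher number of the two, making it the weaker inhibitor. Compound 3 `Cc1cccc(Cc2n[nH]c3cc(O)c(C(=O)N(C)Cc4ccc(F)c(F)c4)cc23)c1` changes the same place: 3,4-difluorophenyl in place of 3,4-dimethoxyphenyl on a saturated chain carbon bound to an amide-type nitrogen. Going by the values given here, the only measured step there, a 12-fold higher number from compound 1 to compound 2 (1.08 log units; beyond the scatter), is large and beyond the scatter. It also bears on the 3,4-dimethoxyphenyl group, which compound 3 lacks, as does compound 1 at 310 nM. A fall in this assay is therefore expected, smaller than that step. The expected change is a 4.1-fold lower number from compound 2 to compound 3 (0.61 log units; beyond the scatter). For compound 3 the estimate is 900 nM, with an expected range of 300 nM to 2700 nM.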

Compound 3, half-maximal inhibitory concentration: 530 nM
Estimate against measurement, compound 3: 1.7-fold (0.23 log units) above; low and high end bracket the measured number.
By their numbers in this assay, from the lowest: compounds 1 and 3 (each within the scatter of the next); then compound 2.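

In this assay, 3,4-difluorophenyl in place of 3,4-dimethoxyphenyl on a saturated chain carbon bound to an amide-type nitrogen gives a 7.0-fold lower number from compound 2 to compound 3 (0.84 log units; beyond the scatter). Replacing 2-bromophenyl with 3,4-difluorophenyl gives a 1.7-fold higher number from compound 1 to compound 3 (0.23 log units; within the scatter), so among these three compounds the high number belongs to the 3,4-dimethoxyphenyl group alone, and two different halogen patterns cannot be told apart. Nothing measured here accounts for these differences.

Open, going by these compounds, is whether both methoxy groups are needed for the higher number seen with compound 2. Also open, on these data alone, is how this position responds to an unsubstituted phenyl, a pyridine ring, or a benzyl group carrying an amine or a carboxylic acid.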